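A few compounds are considered here, and "the series" means these few. Any claim that something is new, unique, unknown or untested is made for them only; others in the source may bear on it.

Among the measured compounds shown here, compound 2 `O=C(/C=C/c1ccc2c(c1)B(O)OC2)c1ccccc1O` is the higher of the two numbers so far measured in a functional assay on HCT-116 cells (Homo sapiens) for cytotoxicity, read by MTT assay, with a stated time of 48 h (a higher number here means a weaker inhibitor, a lower number a stronger inhibitor), where compound 2 gives 77900 nM. Compound 1 `O=C(/C=C/c1ccc2c(c1)B(O)OC2)c1ccccc1F` sits at the other end: in this assay compound 1 gives 4200 nM. For the measured compounds named here, the single measured step connecting them, a 19-fold higher number from compound 1 to compound 2 (1.27 log units; beyond the scatter), is the only one known here. Compound 3 `COc1ccccc1C(=O)/C=C/c1ccc2c(c1)B(O)OC2` has not yet been measured. It differs from compound 2 by methyl in place of hydrogen on an oxygen on an aromatic ring. Going by the values given here, no measured step covers this exact change, so the step from hydroxy to methoxy can only be read indirectly from the fact that removing the hydroxy, in favour of fluoro, gave a much lower number. Capping the same hydroxy with methyl is therefore expected to move the number downward, though by an uncertain amount, perhaps a 3.9-fold lower number from compound 2 to compound 3 (0.59 log units; beyond the scatter). The estimate for compound 3 in this assay is 20000 nM, within a range from 5000 nM to 80000 nM.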

Compound 3, half-maximal inhibitory concentration: 5000 nM
Beside the measured number, compound 3's estimate is 4.0-fold (0.60 log units) above it; measured number inside the range.
By their numbers in this assay, from the lowest: compounds 1 and 3 (each within the scatter of the next); then compound 2.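

In this assay, capping the hydroxy with methyl gives a 16-fold lower number from compound 2 to compound 3 (1.19 log units; beyond the scatter) and leaves an oxygen on the aromatic ring, so the high number of compound 2 goes with the hydroxy and not with oxygen at this place as such. Methoxy and fluoro cannot be told apart here, with a 1.2-fold higher number from compound 1 to compound 3 (0.08 log units; within the scatter) lying within the scatter, so among the three groups at this position only hydroxy stands apart. Nothing measured here explains why the free hydroxy goes with the much higher number.

On these data alone, whether a longer chain on the same oxygen, such as ethoxy, would stay level with compound 1 and compound 3 remains open. So does the reading for an amine or a chloro group at this position.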